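Methyl for Fluoro on the Benzyl Ring: Cytotoxicity Outlook

A few compounds are considered here, and "the series" means these few. Any claim that something is new, unique, unknown or untested is made for them only; others in the source may bear on it.

Compound 1 `CS(=O)(=O)Nc1ccc2c(c1)S(=O)(=O)N=C(C1=C(O)C3CCCC3N(Cc3ccccn3)C1=O)N2` gives > 33000 nM, a limit of the assay.
Compound 2 `CS(=O)(=O)Nc1ccc2c(c1)S(=O)(=O)N=C(C1=C(O)C3CCCC3N(Cc3ccc(F)cn3)C1=O)N2` gives > 33000 nM, a limit of the assay.
Compound 3 `CS(=O)(=O)Nc1ccc2c(c1)S(=O)(=O)N=C(C1=C(O)[C@H]3CCC[C@H]3N(Cc3ccc(F)c(F)c3)C1=O)N2` gives > 1000 nM, a limit of the assay.

All three compounds were tested in an ADME assay on Huh-7 cells (Homo sapiens) for cytotoxicity, with a stated time of 72 h; on this read-out higher numbers stand for lower toxicity in this test and lower numbers for higher toxicity in this test. Compound 1 stands at the limit of > 33000 nM in this assay, at which 2 of the 3 values shown sit, which is a limit and not a number. Compound 2 also stands at the limit of > 33000 nM in this assay, at which 2 of the 3 values shown sit. Because both values are limits, the step that the two limits leave unreadable from compound 1 to compound 2 cannot be read. Compound 3 stands at the limit of > 1000 nM in this assay, at which 1 of the 3 values shown sits, which is again a limit rather than a number, so its position on the scale is known only as a floor.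

Compound 4 `Cc1cc(CN2C(=O)C(C3=NS(=O)(=O)c4cc(NS(C)(=O)=O)ccc4N3)=C(O)[C@H]3CCC[C@H]32)ccc1F` differs from compound 3 by methyl in place of fluoro on an aromatic carbon. Going by the values given here, no measured step bears directly on this change; the only measured step, from compound 1 to compound 2, is unreadable. Every measured compound shows no toxicity up to its limit. Compound 4 is therefore expected to remain at or beyond the limit, with an estimate of 20000 nM, ranging from 3000 nM to 60000 nM. The step that the limit leaves unreadable from compound 3 to compound 4 is expected to be none beyond the scatter.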

Compound 4, half-maximal cytotoxic concentration: > 1000 nM
Compound 4: only a limit was reported; the forecaster's own chance of this, stated with the estimate: 80%; the middle value is on the limit's open side.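

In this assay compound 3 and compound 4 both give limits rather than numbers, so the step between them cannot be read. The compounds shown leave open at what concentration any of them becomes toxic, and whether methyl in place of fluoro changes that concentration.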